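Chloro for fluoro at the aryl ether of compound 3

The compounds below may be only part of what the source reports. "The series", "measured", "known", "first", "only" and "open" are said of these compounds alone.

Compound 3 `CC(Oc1ccc(Oc2ccc(F)cc2)cc1)C(=O)Cn1nnc(-c2ccc(C(=O)O)cc2)n1` gives 2.7 in a physicochemical assay for lipophilicity, read by HPLC, tested at 5 mM (a lower number here means a more polar compound, a higher number a more lipophilic compound), the lowest of the three values recorded. Compound 2 `CCCCCCCCc1ccc(OC(C)C(=O)Cn2nnc(-c3ccc(C(=O)O)cc3)n2)cc1` gives 5.9 and compound 1 `COC(=O)c1ccc(-c2nnn(CC(=O)C(C)Oc3ccc(Oc4ccc(Cl)cc4)cc3)n2)cc1` gives 6.1. Within the data shown here, the only single-point step recorded, a number 3.20 log units lower from compound 2 to compound 3 (beyond the scatter), concerns the other end of the molecule and says nothing directly about a halogen swap. Compound 4 `CC(Oc1ccc(Oc2ccc(Cl)cc2)cc1)C(=O)Cn1nnc(-c2ccc(C(=O)O)cc2)n1` carries chloro in place of fluoro on an aromatic carbon. Among the measured compounds shown here, compound 1 also has the 4-chlorophenoxy group but differs from compound 4 elsewhere as well, so its value is no step. For compound 4 a small rise in this assay is expected, a number 0.50 log units higher from compound 3 to compound 4 (beyond the scatter), giving an estimate of 3.2 with a range from 2.6 to 3.8.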

Compound 4, partition coefficient: 3.3
Estimate against measurement, compound 4: 0.10 log units below; measured number inside the range.
By their numbers in this assay, from the lowest: compound 3; then compound 4; then compounds 2 and 1 (each within the scatter of the next).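

In this assay the halogen on the aromatic carbon para to a large group now has a reading of its own: chloro in place of fluoro gives a number 0.60 log units higher from compound 3 to compound 4 (beyond the scatter) and is a modest step. With the 4-chlorophenoxy group in compound 4, the other two changes are large: 4-chlorophenoxy in place of octyl gives a number 2.60 log units lower from compound 2 to compound 4 (beyond the scatter) and hydrogen in place of methyl gives a number 2.80 log units lower from compound 1 to compound 4 (beyond the scatter) as printed. Nothing measured here gives a reason for the halogen step.

Bromo, methyl or trifluoromethyl at this position remain open. So does the halogen step in a methyl ester pair rather than the carboxylic acid pair.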